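A few compounds are considered here, and "the series" means these few. Any claim that something is new, unique, unknown or untested is made for them only; others in the source may bear on it.

Measured compounds:
Compound 1 `c1ccc2c(c1)CCC2CCCN1CCN(c2cccc3c2OCCO3)CC1` gives 0.16 mg/kg.
Compound 2 `C1=C(CCN2CCN(c3cccc4c3OCCO4)CC2)c2ccccc2CC1` gives 0.63 mg/kg.

Both compounds were tested in a functional assay on the whole organism for antagonist activity, with Rattus norvegicus as the target; a higher number here means that more compound is needed for the effect, a lower number that less compound is needed. Going by the values given here, of the two numbers known, compound 1 has the lowest, so it is the one of which the least is needed for the effect. Compound 2 has the higher number, and the gap between the two lies beyond the usual scatter of repeated measurements, so the two compounds can be told apart with some confidence.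

The next compound, compound 3 `c1ccc2c(c1)CC2CCCCN1CCN(c2cccc3c2OCCO3)CC1`, has not yet been measured. It is built from the same atoms as compound 1, joined differently: a group of 9 heavy atoms (9 carbon; one four-membered non-aromatic ring of carbon only, one six-membered aromatic ring of carbon only) in place of a group of 9 heavy atoms (9 carbon; one five-membered non-aromatic ring of carbon only, one six-membered aromatic ring of carbon only), on a saturated chain carbon, three bonds along the chain from an amine nitrogen in a ring. Among the compounds with values here, no step between two measured compounds shows what such a change does, so the expectation rests on compound 1 alone and on the fact that the change only rearranges atoms without adding or removing any.

For compound 3 a modest step toward a higher number in this assay is expected, namely a 1.9-fold higher number from compound 1 to compound 3 (0.27 log units; within the scatter), because compound 1 gives 0.16 mg/kg and a rearrangement of this kind is not expected to move the number far. Compound 3 is therefore estimated at 0.3 mg/kg, with a range from 0.1 mg/kg to 1 mg/kg.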

Compound 3, minimum effective dose: 5 mg/kg
Compound 3: middle estimate off by 17-fold (1.22 log units), on the low side; measured number outside the range, above it.
By their numbers in this assay, from the lowest: compound 1; then compound 2; then compound 3.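

Replacing the 2,3-dihydro-1H-inden-1-yl group with the group holding a four-membered non-aromatic ring, on a saturated chain carbon, three bonds along the chain from an amine nitrogen in a ring, gives a 31-fold higher number from compound 1 to compound 3 (1.49 log units; beyond the scatter) in this assay, so far more of compound 3 is needed for the effect. The two groups have the same heavy atoms, no hydrogen-bond donors or acceptors and no net charge, which shows that at this position the result can depend strongly on how the same atoms are joined, not just on which atoms are present. Nothing measured here explains why the number rises so far.

This single step cannot separate the effect of ring size from the effect of how the group is joined to the chain, as both differ between compound 1 and compound 3. It also leaves open whether the number would stay low with a seven-membered non-aromatic ring of carbon only, or with a hydroxyl group or an amine on the five-membered ring of compound 1.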